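Replacing pyrrolidin-1-yl with thiophen-2-yl on a carbonyl carbon

The source may hold more compounds than are shown below. What is called first, only, known or untested is meant among the compounds shown, and "the series" means these compounds.

For the measured compounds named here, in a functional assay on BXPC-3 cells (Homo sapiens) for antiproliferative activity, read by sulforhodamine B assay, with a stated time of 72 h (a lower number here means a stronger inhibitor, a higher number a weaker inhibitor), compound 1 `CC(C)(C)c1[nH]cnc1/C=c1\[nH]c(=O)/c(=C/c2cccc(C(=O)N3CCCC3)c2)[nH]c1=O` gives 325 nM and this is the only exact number available. Compound 2 `O=C(c1cccc(/C=c2\[nH]c(=O)/c(=C/c3ccccn3)[nH]c2=O)c1)N1CCC1` gives > 500 nM in this assay and that figure is a limit. Compound 3 `CC(C)(C)c1[nH]cnc1/C=c1\[nH]c(=O)/c(=C/c2cccc(C(=O)c3cccs3)c2)[nH]c1=O` has not yet been measured. It carries thiophen-2-yl in place of pyrrolidin-1-yl on a carbonyl carbon while the rest of compound 1 stays the same. Going by the values given here, no measured pair of compounds gauges this exchange, so any expectation here is a judgement and not a reading from a trend. A shift towards stronger inhibition beyond the usual scatter is expected, though with wide uncertainty, and the result could still arrive as a limit. The expected change is a 5.4-fold lower number from compound 1 to compound 3 (0.73 log units; beyond the scatter) in this assay on this estimate. For compound 3 the estimated value is 60 nM with an expected range from 10 nM to 350 nM in the same test.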

Compound 3, half-maximal inhibitory concentration: 1.72 nM
Compound 3: the middle estimate sits 35-fold (1.54 log units) above what was measured; measured number outside the range, below it.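

In this assay, putting thiophen-2-yl in place of pyrrolidin-1-yl on a carbonyl carbon gives a 190-fold lower number from compound 1 to compound 3 (2.28 log units; beyond the scatter), so this position responds very strongly to the group carried by the carbonyl. The two groups are both five-membered rings with one hetero atom and have the same count of heavy atoms, yet the amide of compound 1 and the ketone of compound 3 lie far apart in this test. No measurement shown bears on why the step is so large.

The compounds shown leave open whether a phenyl ring or furan-2-yl on the carbonyl carbon would match thiophen-2-yl, or whether dimethylamino would match pyrrolidin-1-yl. Compound 2 gives > 500 nM as a limit and differs from compound 1 in more than one place, so it does not inform this exchange.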